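A methoxy to ethoxy step at the assay ceiling

This account rests on a few compounds, and the source may have more. Where it says the series, first, only, none or still open, it means among the compounds named here.

Compound 1 `N#CC1=C(N)Oc2c(c3nc4ccccc4nc3c3ccccc23)C12C(=O)N(Cc1cnnn1-c1ccc(Br)cc1)c1ccccc12` gives in a functional assay on A549 cells (Homo sapiens) for antiproliferative activity, read by MTT assay, with a stated time of 48 h (on this read-out lower numbers stand for stronger inhibition and higher numbers for weaker inhibition), 44300 nM.
Compound 2 `N#CC1=C(N)Oc2c(c3nc4ccccc4nc3c3ccccc23)C12C(=O)N(Cc1cnnn1-c1cccc(Br)c1)c1ccccc12` reaches only a limit in this assay: > 50000 nM.
Compound 3 `COc1ccc(-n2nncc2CN2C(=O)C3(C(C#N)=C(N)Oc4c3c3nc5ccccc5nc3c3ccccc43)c3ccccc32)cc1` likewise reaches only a limit in this assay: > 50000 nM.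

Compound 3 thus stands at the ceiling of what this assay reports, a place it shares with one other compound, as the limit of > 50000 nM in this assay, at which 2 of the 3 values shown sit, notes. Compound 4 `CCOc1ccc(-n2nncc2CN2C(=O)C3(C(C#N)=C(N)Oc4c3c3nc5ccccc5nc3c3ccccc43)c3ccccc32)cc1` differs from compound 3 by methyl in place of hydrogen on a saturated chain carbon bound to an oxygen on an aromatic ring. The measured steps all concern the aryl group on the aromatic nitrogen, not this chain: an at least 1.1-fold higher number from compound 1 to compound 2 (0.05 log units; that floor lies within the scatter), an at least 1.1-fold higher number from compound 1 to compound 3 (0.05 log units; that floor lies within the scatter), and a step that the two limits leave unreadable from compound 2 to compound 3. None shows a shift beyond the scatter, and none tests a lengthened chain. Compound 4 is therefore expected to remain at or near the limit, with a step that the limit leaves unreadable from compound 3 to compound 4. The estimate for compound 4 is 60000 nM, within 30000 nM to 150000 nM.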

Compound 4, half-maximal inhibitory concentration: 25200 nM
For compound 4 the middle estimate is 2.4-fold (0.38 log units) above the measured one; the whole stated range lies above it.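

On the 4-methoxyphenyl group, going from methoxy to ethoxy turns a limit into a measured number in this assay, with an at least 1.9-fold lower number from compound 3 to compound 4 (0.29 log units; that floor lies within the scatter). That size is only a floor, since the starting value is a limit: the limit of > 50000 nM in this assay, at which 2 of the 4 values shown sit. The change from the 3-bromophenyl group gives an at least 1.9-fold lower number from compound 2 to compound 4 (0.29 log units; that floor lies within the scatter), and ethoxy in place of bromo gives a 1.8-fold lower number from compound 1 to compound 4 (0.25 log units; within the scatter), so compound 1 and compound 4 cannot be told apart. From the compounds shown here alone, whether a longer chain such as propoxy, or an amine in place of ethoxy, would shift the number further remains open.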